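Series notes: from compound 3 to compound 4

The compounds below may be only part of what the source reports. "The series", "measured", "known", "first", "only" and "open" are said of these compounds alone.

Measured values in a functional assay on OVCAR-3 cells (Homo sapiens) for cytotoxicity, read by sulforhodamine B assay; a lower number here means that less compound is tolerated, a higher number that more compound is tolerated:
- compound 1 `CC1=CC[C@@H]([C@@](C)(O)CCCC(C)(C)NC(=S)N/N=C\c2ccccc2)CC1`: 43600 nM
- compound 2 `CC1=CC[C@@H]([C@@](C)(O)CCCC(C)(C)NC(=S)N/N=C\c2ccccc2Cl)CC1`: a limit of this assay, > 100000 nM
- compound 3 `CC1=CC[C@@H]([C@@](C)(O)CCCC(C)(C)NC(=S)N/N=C\c2cccc(Cl)c2)CC1`: 48000 nM

Compound 3 gives the highest of the two numbers; compound 1 sits within the scatter of it, and the third value is a limit. Compound 4 `CC1=CC[C@@H]([C@@](C)(O)CCCC(C)(C)NC(=S)N/N=C(/C)c2ccccc2)CC1` differs from compound 3 by a group of 9 heavy atoms (8 carbon, 1 nitrogen; one six-membered aromatic ring of carbon only) in place of a group of 9 heavy atoms (7 carbon, 1 nitrogen, 1 chlorine; one six-membered aromatic ring of carbon only), on an amide-type nitrogen. The measured steps that bear on this concern the chloro only: a 1.1-fold higher number from compound 1 to compound 3 (0.04 log units; within the scatter), an at least 2.2-fold higher number from compound 1 to compound 2 (0.36 log units; beyond the scatter) and an at least 2.0-fold lower number from compound 2 to compound 3 (0.31 log units; beyond the scatter). Within the data shown here, removing the chloro from compound 3 thus points back toward compound 1; the added methyl on the carbon doubly bonded to nitrogen has no measured counterpart. The expected step is therefore a 1.1-fold lower number from compound 3 to compound 4 (0.03 log units; within the scatter), within the scatter. Compound 4 is estimated at 45000 nM, between 15000 nM and 110000 nM.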

Compound 4, concentration lethal to 50% of the cells: > 100000 nM
Compound 4: a limit, no number (the forecaster's own chance of this, stated with the estimate: 30%); at least 2.2-fold (0.34 log units) between middle value and limit.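

In this assay compound 4 gives a limit, not a number: > 100000 nM. A methyl on the carbon doubly bonded to nitrogen gives an at least 2.2-fold higher number from compound 1 to compound 4 (0.36 log units; beyond the scatter), and the same methyl with loss of the chloro gives an at least 2.0-fold higher number from compound 3 to compound 4 (0.31 log units; beyond the scatter), so a change at this carbon, and not only on the aromatic ring, can raise the number. The step between compound 2 and compound 4 cannot be read: the limit of > 100000 nM in this assay, at which 2 of the 4 values shown sit.

From the compounds shown here alone, how far compound 4 lies past its limit stays open. Also open, going by these compounds, is whether an ethyl group or a carboxylic acid on this carbon would follow the methyl.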